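The source may hold more compounds than are shown below. What is called first, only, known or untested is meant among the compounds shown, and "the series" means these compounds.

Compound 1 `Fc1cc2nc(-c3cccnc3)n(C3CC3)c2cc1F` is measured in an assay on V79 cells for inhibition of cytochrome P450 11B1, mitochondrial (Homo sapiens), read by HTRF, with a stated time of 1 h (a higher number here means a weaker inhibitor, a lower number a stronger inhibitor), at 370 nM. Of the three compounds with numbers, compound 1 has the lowest, yet both neighbours sit within the scatter of it: compound 2 `Cc1ccncc1-c1nc2cc(F)c(F)cc2n1C1CC1` gives 723 nM, and compound 3 `Fc1ccc2nc(-c3cccnc3)n(C3CC3)c2c1` gives 401 nM. The step of a 2.0-fold higher number from compound 1 to compound 2 (0.29 log units; within the scatter) and the step of a 1.1-fold higher number from compound 1 to compound 3 (0.03 log units; within the scatter) are both small. Compound 4 `Fc1ccc2c(c1)nc(-c1cccnc1)n2C1CC1` differs from compound 1 by hydrogen in place of fluoro on an aromatic carbon. For the measured compounds named here, the one comparable step, from compound 1 to compound 3, also removed a fluoro from the same ring and stayed within the scatter, so no shift beyond the scatter is expected in this assay, that is a 1.1-fold higher number from compound 1 to compound 4 (0.06 log units; within the scatter). For compound 4 the expected value is 420 nM, between 200 nM and 900 nM.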

Compound 4, half-maximal inhibitory concentration: 3980 nM
For compound 4 the middle estimate is 9.5-fold (0.98 log units) below the measured one, outside the stated range (above it).
By their numbers in this assay, from the lowest: compounds 1, 3 and 2 (each within the scatter of the next); then compound 4.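

Hydrogen in place of fluoro is not a neutral change at every place on this ring: here it gives an 11-fold higher number from compound 1 to compound 4 (1.03 log units; beyond the scatter), whereas the same swap at the other fluoro gives a 1.1-fold higher number from compound 1 to compound 3 (0.03 log units; within the scatter), within the scatter. So the two fluoro groups of compound 1 do not count equally, and this one, on the aromatic carbon meta to a fused ring in the description of the change, carries the difference. Nothing available explains why the two places differ. Still open, from the compounds shown here alone, is whether fluoro itself is needed at this place, or whether another group, such as chloro, methoxy or an amine, would serve as well.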